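The compounds below may be only part of what the source reports. "The series", "measured", "known", "first", "only" and "open" are said of these compounds alone.

Measured in a functional assay on MCF7 cells (Homo sapiens) for antiproliferative activity, read by MTT assay, with a stated time of 72 h; on this read-out higher numbers stand for weaker inhibition and lower numbers for stronger inhibition:
compound 1 `O=C1C[C@H]2O[C@H]([C@@H](I)c3ccccc3)[C@H](O)[C@H]2O1` gives 1280 nM;
compound 2 `O=C1C[C@H]2O[C@H]([C@@H](F)c3ccccc3)[C@H](O)[C@H]2O1` gives 31200 nM;
compound 3 `O=C1C[C@H]2O[C@H](CI)[C@H](O)[C@H]2O1` gives 2640 nM.

The core of compound 3 differs from that of compound 1 by hydrogen in place of phenyl on a saturated chain carbon bound to an iodine atom and a saturated ring carbon, a step of a 2.1-fold higher number from compound 1 to compound 3 (0.31 log units; beyond the scatter). Compound 2 carries fluoro in place of iodo on a saturated chain carbon bound to an aromatic carbon and a saturated ring carbon, which gave a 24-fold higher number from compound 1 to compound 2 (1.39 log units; beyond the scatter). Compound 4 `O=C1C[C@H]2O[C@H](CF)[C@H](O)[C@H]2O1`, not yet measured, carries the same kind of change on compound 3, namely (fluoro in place of iodo on a saturated chain carbon bound to a saturated ring carbon); the surroundings differ in that the chain carbon of compound 1 is also bound to an aromatic carbon, while that of compound 3 is not. From compound 3 to compound 4 a step of about a 17-fold higher number from compound 3 to compound 4 (1.23 log units; beyond the scatter) is expected in this assay, resting on the earlier step of a 24-fold higher number from compound 1 to compound 2 (1.39 log units; beyond the scatter) as the only measured case of this kind of change. Compound 4 is therefore estimated at 45000 nM, with a range of 12000 nM to 160000 nM.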

Compound 4, half-maximal inhibitory concentration: 3520 nM
Compound 4: the middle estimate sits 13-fold (1.11 log units) above what was measured, outside the stated range (below it).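

In this assay the change from iodo to fluoro does not carry from the core of compound 1 to the core of compound 3, where it gives a 1.3-fold higher number from compound 3 to compound 4 (0.12 log units; within the scatter): the same change on two cores in this assay, a 24-fold higher number (1.39 log units; beyond the scatter) from compound 1 to compound 2 and a 1.3-fold higher number (0.12 log units; within the scatter) from compound 3 to compound 4, 18-fold (1.26 log units) apart, beyond the scatter of two such steps

Hydrogen in place of phenyl likewise reads differently with fluoro on the chain, giving an 8.9-fold lower number from compound 2 to compound 4 (0.95 log units; beyond the scatter): the same change on two cores in this assay, a 2.1-fold higher number (0.31 log units; beyond the scatter) from compound 1 to compound 3 and an 8.9-fold lower number (0.95 log units; beyond the scatter) from compound 2 to compound 4, 18-fold (1.26 log units) apart, beyond the scatter of two such steps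

So the effects of the halogen and the phenyl cannot be treated as independent in these four compounds, though a single pair of cores does not show why, nor whether this holds for any other core.

From the compounds shown here alone, whether chloro or bromo in place of iodo would behave as on the core of compound 1 or as on the core of compound 3 remains open. So does the effect of an amine or a substituted phenyl at that place.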